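The compounds below may be only part of what the source reports. "The series", "measured", "known", "first", "only" and "open" are said of these compounds alone.

In a functional assay on HL-60 cells (Homo sapiens) for cytotoxicity, read by CellTiter-Blue, with a stated time of 48 h (a higher number here means a weaker inhibitor, a lower number a stronger inhibitor), compound 1 `CCOC(=O)CC1C(C(=O)OCC)=C(N)Oc2ccc(-c3cc(F)cc(F)c3)cc21` gives 35900 nM. Compound 2 `CCOC(=O)CC1C(C(=O)OCC)=C(N)Oc2ccc(-c3ccco3)cc21` stands only as a limit, > 80000 nM, so no exact number is available for it. Compound 3 `CCOC(=O)CC1C(C(=O)OCC)=C(N)Oc2ccc(-c3cccs3)cc21` differs from it in one place: thiophen-2-yl in place of furan-2-yl on an aromatic carbon, with thiophen-2-yl in place of furan-2-yl on an aromatic carbon. Among the measured compounds shown here, only one measured step bears on this change, an at least 2.2-fold higher number from compound 1 to compound 2 (0.34 log units; beyond the scatter). That step lies beyond the scatter, but it involves 3,5-difluorophenyl rather than a second five-membered aromatic ring with 1 hetero atom, so it gives only an indirect guide. On that step, compound 3 is expected to remain a weak inhibitor in this assay, with no change beyond the scatter expected. The expected step is an at least 1.3-fold lower number from compound 2 to compound 3 (0.12 log units; that floor lies within the scatter). For compound 3 the estimated value is 60000 nM, with an expected range of 30000 nM to 100000 nM.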

Compound 3, half-maximal inhibitory concentration: > 80000 nM
Compound 3: no number, only a limit (the forecaster's own chance of this, stated with the estimate: 45%); middle value at least 1.3-fold (0.12 log units) from the limit.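

In this assay, thiophen-2-yl on this aromatic carbon in place of 3,5-difluorophenyl gives an at least 2.2-fold higher number from compound 1 to compound 3 (0.34 log units; beyond the scatter). The drop against compound 1 seen with furan-2-yl therefore also appears with sulfur instead of oxygen in the five-membered aromatic ring, so it does not depend on that one hetero atom in these two compounds. The exchange of furan-2-yl for thiophen-2-yl itself cannot be read, because compound 2 and compound 3 both end at a limit and not at a number: the limit of > 80000 nM in this assay, at which 2 of the 3 values shown sit.

Going by these compounds, how far apart compound 2 and compound 3 truly lie remains open. Also open, on these data alone, is how an unsubstituted phenyl ring, an amine or a carboxylic acid on this aromatic carbon would read in this assay.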